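Phenyl for Dichlorophenyl on a Spirocyclic Integrin Antagonist

The source may report more compounds than this note shows. Statements on the series, on what has been measured and on what is new or still open speak of the compounds shown alone.

Measured compounds in a functional assay for antagonist activity at integrin alpha-5/beta-1 (Homo sapiens), read by ELISA; on this read-out lower numbers stand for stronger inhibition and higher numbers for weaker inhibition:
compound 1 `Cc1cc(C)c(S(=O)(=O)N[C@@H](CNC(=O)C2=NO[C@]3(CN[C@H](CNc4ncc[nH]4)C3)C2)C(=O)O)c(C)c1` — 230 nM
compound 2 `Cc1cc(C)c(S(=O)(=O)N[C@@H](CNC(=O)C2=NO[C@@]3(C2)C[C@@H](CNC2N=CC=N2)N(C(=O)OCc2ccccc2)C3)C(=O)O)c(C)c1` — 1200 nM
compound 3 `O=C(NC[C@@H](C(=O)O)S(=O)(=O)c1c(Cl)cccc1Cl)C1=NOC2(CCC(CNc3ncc[nH]3)CC2)C1` — 3000 nM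

Compound 3 gives the highest number of the three. Its nearest neighbour is compound 2, which in this assay gives 1200 nM, a gap beyond the scatter, and the furthest is compound 1, which in this assay gives 230 nM, a still wider gap. Compound 3 is therefore the weakest inhibitor of the set on these numbers.

Compound 4 `O=C(NC[C@@H](C(=O)O)S(=O)(=O)c1ccccc1)C1=NOC2(CCC(CNc3ncc[nH]3)CC2)C1` differs from compound 3 in one place: phenyl in place of 2,6-dichlorophenyl on a sulfonyl sulfur. Among the compounds with values here, both compounds 1 and 2 carry a substituted aryl group on the sulfonyl sulfur, and no measured compound shows an unsubstituted one, so no step in this assay speaks to this change directly. A moderate loss in this assay, beyond the scatter, is expected for compound 4, with the step from compound 3 estimated as a 2.7-fold higher number from compound 3 to compound 4 (0.43 log units; beyond the scatter). Compound 4 is thus expected to give about 8000 nM in this assay, within a range from 2500 nM to 25000 nM.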

Compound 4, half-maximal inhibitory concentration: 4700 nM
The estimate for compound 4 lay 1.7-fold (0.23 log units) above the measured number, within the range that was stated.
By their numbers in this assay, from the lowest: compound 1; then compound 2; then compounds 3 and 4 (each within the scatter of the next).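

Placing phenyl instead of 2,6-dichlorophenyl on the sulfonyl sulfur gives, in this assay, a 1.6-fold higher number from compound 3 to compound 4 (0.19 log units; within the scatter), the first direct reading of this position, which compounds 1 and 2 could not supply. With the shared core of compounds 3 and 4 held constant, this read-out does not separate the two aryl groups, so the two chlorine atoms leave no mark here that stands out from repeat scatter. Nothing measured on these compounds speaks to the reason for this result.

Compounds 1 and 2 differ from compounds 3 and 4 in more than one place, so their lower numbers cannot be assigned to the aryl group on the sulfonyl sulfur. On these data alone, whether a methoxy group or a fluorine atom on the phenyl would read any differently on this core stays open.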